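The source may report more compounds than this note shows. Statements on the series, on what has been measured and on what is new or still open speak of the compounds shown alone.

Measured so far in an assay on isolated protein for inhibition of 3-hydroxy-3-methylglutaryl-coenzyme A reductase (Homo sapiens); on this read-out lower numbers stand for stronger inhibition and higher numbers for weaker inhibition:
Compound 1 `CCC(C)(C)C(=O)O[C@@H]1C2C(=C[C@H](C)[C@@H]1O)C=C[C@H](C)[C@@H]2CC[C@@H]1C[C@@H](O)CC(=O)O1`, with 13.3 nM.
Compound 2 `CCC(C)(C)C(=O)O[C@@H]1C2C(=C[C@H](C)[C@H]1[C@H](C)O)C=C[C@H](C)[C@@H]2CC[C@@H]1C[C@@H](O)CC(=O)O1`, with 7.6 nM.

The numbers of compound 1 and compound 2 fall within the usual scatter of repeated measurements of each other, so the two cannot be ranked on these data; compound 2 simply has the smaller of the two figures. Compound 3 `CCC(C)(C)C(=O)O[C@@H]1C2C(=C[C@H](C)[C@H]1[C@@H](O)c1ccccc1)C=C[C@H](C)[C@@H]2CC[C@@H]1C[C@@H](O)CC(=O)O1` has not yet been measured. It differs from compound 2 in one place: phenyl in place of methyl on a saturated chain carbon bound to an oxygen on a saturated carbon and a saturated ring carbon. For the measured compounds named here, no pair of measured compounds shows a change of this kind, so there is no measured step to lean on. For compound 3 the step of a 1.8-fold higher number from compound 2 to compound 3 (0.27 log units; within the scatter) is expected to be modest, most likely towards a somewhat larger number, though a change no greater than the scatter would not surprise. The estimate for compound 3 in this assay is 14 nM, with a range from 4 nM to 50 nM.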

Compound 3, half-maximal inhibitory concentration: 19.7 nM
Beside the measured number, compound 3's estimate is 1.4-fold (0.15 log units) below it, and the stated range covers the measured number.
By their numbers in this assay, from the lowest: compounds 2, 1 and 3 (each within the scatter of the next, the first and the last beyond it).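

For the compounds shown here, at the saturated chain carbon bound to an oxygen, the change from 1-hydroxyethyl to hydroxy(phenyl)methyl gives the first step at this position that lies beyond the scatter in this assay: a 2.6-fold higher number from compound 2 to compound 3 (0.41 log units; beyond the scatter). The step is modest, so this place can carry a phenyl ring of six carbons with inhibition largely kept, and compound 3 still gives 19.7 nM. Nothing measured here says why the number rises.

From the compounds shown here alone, whether the rise goes with the aromatic ring or simply with a larger group stays open; a saturated cyclohexyl ring or a longer chain in the same place would separate the two. Also open, going by these compounds, is how a group added to the phenyl ring, such as an amine or a carboxylic acid, would shift the number.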